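Cyano to nitro: working notes on compound 3

The compounds below may be only part of what the source reports. "The series", "measured", "known", "first", "only" and "open" are said of these compounds alone.

- Compound 1 `Cc1nsc(-c2ccc(N3CCN(c4cccc(Cl)c4)CC3)nn2)n1`: 0.6 nM
- Compound 2 `Cc1nsc(-c2ccc(N3CCN(c4cccc(C#N)c4)CC3)nn2)n1`: 3 nM

Both values come from a functional assay (aorta) for inhibition, with Rattus norvegicus as the target; a lower number here means a stronger inhibitor, a higher number a weaker inhibitor. Compound 2 has the higher of the two numbers, making it the weaker inhibitor of the pair. Compound 3 `Cc1nsc(-c2ccc(N3CCN(c4cccc([N+](=O)[O-])c4)CC3)nn2)n1` carries nitro in place of cyano on an aromatic carbon. Going by the values given here, one measured step bears on this change: a 5.0-fold higher number from compound 1 to compound 2 (0.70 log units; beyond the scatter), which is modest. Among the compounds with values here, no measured compound carries nitro, so the direction stays open, and a small step is expected. The expected change is a 1.5-fold lower number from compound 2 to compound 3 (0.18 log units; within the scatter). The estimate for compound 3 is 2 nM, with an expected range from 0.5 nM to 8 nM.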

Compound 3, half-maximal inhibitory concentration: 3 nM
Compound 3: middle estimate off by 1.5-fold (0.18 log units), on the low side; the range from low to high includes it.
By their numbers in this assay, from the lowest: compound 1; then compounds 2 and 3 (each within the scatter of the next).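

In this assay, nitro in place of cyano gives no change at the digits printed from compound 2 to compound 3 (within the scatter) at this aromatic carbon, so the two groups cannot be told apart here, although they differ in heavy atoms and hydrogen-bond acceptors. Nitro in place of chloro gives a 5.0-fold higher number from compound 1 to compound 3 (0.70 log units; beyond the scatter) and matches a 5.0-fold higher number from compound 1 to compound 2 (0.70 log units; beyond the scatter) in size, leaving compound 1 with the lowest number of the three. No measurement shown here accounts for either step. Going by these compounds, whether an amine or a carboxylic acid at this carbon would track chloro, or cyano and nitro, remains open.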